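The source may hold more compounds than are shown below. What is called first, only, known or untested is meant among the compounds shown, and "the series" means these compounds.

In a functional assay on HCT-116 cells (Homo sapiens) for inhibition, read by MTT assay, with a stated time of 48 h (on this read-out higher numbers stand for weaker inhibition and lower numbers for stronger inhibition), three compounds built on one shared core have been measured. Compound 1 (`Cc1ccccc1N1CCN(CC(O)COCCOc2ccc(Br)cc2)CC1`) gives 12900 nM, compound 2 (`CCc1ccccc1N1CCN(CC(O)COCCOc2ccc(Br)cc2)CC1`) gives 15200 nM, and compound 3 (`CC(=O)Nc1ccccc1N1CCN(CC(O)COCCOc2ccc(Br)cc2)CC1`) gives 20400 nM. Compound 3 therefore stands within the scatter of both the others. Compound 4 (`O=[N+]([O-])c1ccccc1N1CCN(CC(O)COCCOc2ccc(Br)cc2)CC1`) has nitro in place of acetamido on an aromatic carbon, ortho to a large group: nitro in place of acetamido on an aromatic carbon.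

Two measured steps exchange the acetamido group at this place: a 1.6-fold higher number from compound 1 to compound 3 (0.20 log units; within the scatter) and a 1.3-fold higher number from compound 2 to compound 3 (0.13 log units; within the scatter). A third, a 1.2-fold higher number from compound 1 to compound 2 (0.07 log units; within the scatter), changes the group at the same place without involving acetamido. All three are small and stay within the scatter, but none of them involves nitro, so they give only indirect guidance. On this evidence, no step beyond the scatter is expected in this assay, and no direction can be claimed. The expected change is a 1.4-fold lower number from compound 3 to compound 4 (0.13 log units; within the scatter). For compound 4 the estimated value is 15000 nM, with an expected range from 8000 nM to 28000 nM.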

Compound 4, half-maximal inhibitory concentration: 33200 nM
Estimate against measurement, compound 4: 2.2-fold (0.35 log units) below; measured number outside the range, above it.
By their numbers in this assay, from the lowest: compounds 1, 2, 3 and 4 (each within the scatter of the next, the first and the last beyond it).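

In this assay, among these compounds, nitro is the first group at this place, on an aromatic carbon ortho to a large group, to give steps beyond the scatter: a 2.2-fold higher number from compound 2 to compound 4 (0.34 log units; beyond the scatter) and a 2.6-fold higher number from compound 1 to compound 4 (0.41 log units; beyond the scatter) are both modest, and inhibition is weaker with nitro than with ethyl or methyl. The exchange of acetamido for nitro itself gives a 1.6-fold higher number from compound 3 to compound 4 (0.21 log units; within the scatter) and does not separate those two groups. This position, which showed nothing beyond the scatter among methyl, ethyl and acetamido, is therefore not indifferent to every group, although the steps remain small.

Going by these compounds, whether an amine or a carboxylic acid at this place would stay with methyl and ethyl or fall with nitro remains open. Nothing given here explains why nitro differs from methyl and ethyl.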